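Two Inactive Compounds and a Naphthyl Replacement

The source may hold more compounds than are shown below. What is called first, only, known or untested is meant among the compounds shown, and "the series" means these compounds.

Compound 1 `Cc1ccc(-c2csc(N3N=C(c4ccc(N5CCCCC5)cc4)CC3c3ccc(Cl)cc3)n2)cc1` gives in a functional assay on A-375 cells (Homo sapiens) for antiproliferative activity, read by MTT assay, with a stated time of 72 h (a higher number here means a weaker inhibitor, a lower number a stronger inhibitor), the value > 100000 nM, which is a limit of the assay and not a number.
Compound 2 `CS(=O)(=O)c1ccc(-c2csc(N3N=C(c4ccc(N5CCCCC5)cc4)CC3c3ccc(Cl)cc3)n2)cc1` gives in this assay the value > 100000 nM, likewise a limit and not a number.

Compound 2 therefore stands at the upper edge of what this assay reports. Both values shown in this assay sit at the same place, (the limit of > 100000 nM in this assay, at which 2 of the 2 values shown sit), so neither compound gives a readable number. Within the data shown here, the one measured step, a step that the two limits leave unreadable from compound 1 to compound 2, is left unreadable by the two limits, and its size cannot be stated.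

Compound 3 `Clc1ccc(C2CC(c3ccc(N4CCCCC4)cc3)=NN2c2nc(-c3ccc4ccccc4c3)cs2)cc1` differs from compound 2 by naphthalen-2-yl in place of 4-(methylsulfonyl)phenyl on an aromatic carbon. That change touches the same position as the measured step, but because a step that the two limits leave unreadable from compound 1 to compound 2 is unreadable, it offers no guidance on size or direction. What remains is that both shown values rest on the limit (the limit of > 100000 nM in this assay, at which 2 of the 2 values shown sit), and the expectation for compound 3 is built on that alone.

Compound 3 is therefore expected to return about 100000 nM, within a range from 30000 nM to 300000 nM. The expected step of a number no higher from compound 2 to compound 3 (the limit leaves the size open) is estimated to be none beyond the usual scatter, with a real chance that only a limit is reported again.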

Compound 3, half-maximal inhibitory concentration: > 100000 nM
Compound 3 was reported as a limit (the forecaster's own chance of this, stated with the estimate: 70%); the middle value sits exactly at the limit.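

In this assay compound 3 gives > 100000 nM, a limit and not a number, so the steps linking compound 3 with compound 1 and compound 2 cannot be read. The compounds shown leave open whether 4-methylphenyl, 4-(methylsulfonyl)phenyl and naphthalen-2-yl differ at all in their effect, as all three values rest on one limit: the limit of > 100000 nM in this assay, at which 3 of the 3 values shown sit.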